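Compound 3: 4-carbamoylpiperidin-1-yl in place of chloro

The source may report more compounds than this note shows. Statements on the series, on what has been measured and on what is new or still open speak of the compounds shown alone.

Values measured in an ADME assay on J774.1 cells (Mus musculus) for cytotoxicity, read by resazurin assay, with a stated time of 48 h; on this read-out lower numbers stand for stronger inhibition and higher numbers for weaker inhibition:
- compound 1 `CCCn1cc(C(=O)NCc2ccccc2)c(=O)c2cc(F)c(N3CCC(C(N)=O)CC3)cc21`: 43700 nM
- compound 2 `CCCn1cc(C(=O)O)c(=O)c2cc(F)c(Cl)cc21`: > 100000 nM

In this assay compound 2 reads > 100000 nM, and this value is a limit of the assay, not a number. Within the data shown here, compound 2 thus stands at the limit of > 100000 nM in this assay, at which 1 of the 2 values shown sits, so no measured step starts from it.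

The next compound is compound 3 `CCCn1cc(C(=O)O)c(=O)c2cc(F)c(N3CCC(C(N)=O)CC3)cc21`, which has 4-carbamoylpiperidin-1-yl in place of chloro on an aromatic carbon. Everything else matches compound 2. Compound 1 carries the same 4-carbamoylpiperidin-1-yl but differs from compound 3 in a second place. Among the measured compounds shown here, compound 1 gives 43700 nM as the only numerical reading.

For the measured compounds named here, with that reading as the sole guide, compound 3 is expected to remain weak in this assay, close to the limit, with no change beyond the scatter and a limit reading quite possible. The expected size of the change is an at least 1.1-fold lower number from compound 2 to compound 3 (0.04 log units; that floor lies within the scatter) in this estimate. For compound 3 the estimated value is 90000 nM, with an expected range from 40000 nM to 200000 nM.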

Compound 3, half-maximal inhibitory concentration: > 100000 nM
Compound 3: no number, only a limit; the forecaster's own chance of this, stated with the estimate: 60%; at least 1.1-fold (0.04 log units) between middle value and limit.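

In this assay the reading of compound 3 is a limit of the assay and not a number, so the exchange of chloro for 4-carbamoylpiperidin-1-yl on the aromatic carbon cannot be read as a step: the limit of > 100000 nM in this assay, at which 2 of the 3 values shown sit.

The readable change lies elsewhere in the molecule: hydroxy in place of benzylamino on the carbonyl carbon gives an at least 2.2-fold higher number from compound 1 to compound 3 (0.35 log units; beyond the scatter). Among the compounds shown, 4-carbamoylpiperidin-1-yl on the aromatic carbon therefore does not by itself bring a numerical reading, since the only one goes with the benzylamino form, compound 1.

Open, on these data alone, is whether a benzylamino form carrying chloro on that aromatic carbon would give a number in this assay, which would show what 4-carbamoylpiperidin-1-yl contributes to the benzylamino series at this position. Also open, as far as these compounds go, is how far the reading on the carbonyl carbon depends on the benzyl part itself, which a methylamino or a phenethylamino group there would test.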